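This account rests on a few compounds, and the source may have more. Where it says the series, first, only, none or still open, it means among the compounds named here.

Measured so far:
compound 1 `CCCCOc1ccc(Nc2nc3nonc3nc2O)cc1` — 3700 nM
compound 2 `Oc1nc2nonc2nc1Nc1ccc(OCCCC(F)(F)F)c(F)c1` — 4200 nM

In an assay on mitochondria from L6 cells (Rattus norvegicus) for activation, with a stated time of 90 min (on this read-out higher numbers stand for an effect only at larger amounts of compound and lower numbers for an effect already at smaller amounts), compound 1 gives 3700 nM. Compound 2 gives 4200 nM, and the two numbers sit within the usual scatter of each other, so neither compound can be set apart from the other on this read-out. Compound 3 `Oc1nc2nonc2nc1Nc1ccc(S(F)(F)(F)(F)F)cc1` has not yet been measured. It differs from compound 1 in one place: a group of 6 heavy atoms (5 fluorine, 1 sulfur; no ring) in place of a group of 5 heavy atoms (4 carbon, 1 oxygen; no ring), on an aromatic carbon. The butoxy group leaves and the incoming group takes its place on the same aromatic carbon. Within the data shown here, no step between measured compounds shows what such a change does in this assay, so the expectation rests on the two measured values alone, which lie close together although their side groups differ. A step of a 1.1-fold higher number from compound 1 to compound 3 (0.03 log units; within the scatter) is expected, within the scatter rather than beyond it. Compound 3 is therefore estimated at 4000 nM, with a range from 1500 nM to 11000 nM.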

Compound 3, half-maximal effective concentration: 3900 nM
Estimate against measurement, compound 3: 1.0-fold (0.01 log units) above; low and high end bracket the measured number.
By their numbers in this assay, from the lowest: compounds 1, 3 and 2 (each within the scatter of the next).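

In this assay, a group of 6 heavy atoms (5 fluorine, 1 sulfur; no ring) in place of butoxy gives a 1.1-fold higher number from compound 1 to compound 3 (0.02 log units; within the scatter), so the read-out does not tell these two groups apart at this position. Among these compounds, this is the first one-place step among the compounds, and it shows that the butoxy chain, with its hydrogen-bond acceptor, can be exchanged on this aromatic carbon for a group without a ring or a hydrogen-bond acceptor, with no difference beyond the scatter. Nothing measured here bears on why the two numbers lie so close.

The compounds shown leave open whether an amine, a carboxylic acid or a longer chain on the same aromatic carbon would also fall within the scatter. A single step also cannot show whether this holds for other positions on the shared core.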